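The source may hold more compounds than are shown below. What is called first, only, known or untested is meant among the compounds shown, and "the series" means these compounds.

Working notes on the series, read in an ADME assay on Akata cells (Homo sapiens) for cytotoxicity, with a stated time of 7 days; on this read-out higher numbers stand for lower toxicity in this test and lower numbers for higher toxicity in this test. Compound 1 `COCCOc1nc(N)nc2c1ncn2/C=C1/CC1(CO)CO` gives > 20000 nM, which is a limit of the assay and not a number. Compound 2 `CCCCSc1nc(N)nc2c1ncn2/C=C1/CC1(CO)CO` gives > 20000 nM, again only a limit. The whole measured picture is therefore (the limit of > 20000 nM in this assay, at which 2 of the 2 values shown sit). Going by the values given here, the single measured step, a step that the two limits leave unreadable from compound 1 to compound 2, has no readable size and offers no scale for the next change.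

Compound 3 `CCCCNc1nc(N)nc2c1ncn2/C=C1/CC1(CO)CO` carries butylamino in place of butylsulfanyl on an aromatic carbon. With no readable step to draw on, no shift beyond the scatter is expected in this assay, and a further limit is the likeliest report. The expected move is a number no higher from compound 2 to compound 3 (the limit leaves the size open). Compound 3 is estimated at 20000 nM, with an expected range from 8000 nM to 40000 nM.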

Compound 3, half-maximal cytotoxic concentration: > 24000 nM
Compound 3: only a limit was reported; the forecaster's own chance of this, stated with the estimate: 70%; middle value at least 1.2-fold (0.07 log units) from the limit.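

Going by these compounds alone, compound 1, compound 2 and compound 3 all report limits of the assay and not numbers, and no step among them can be read. The compounds shown leave open what half-maximal cytotoxic concentration butylamino, butylsulfanyl or 2-methoxyethoxy on the shared core would give in this assay.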